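This account rests on a few compounds, and the source may have more. Where it says the series, first, only, none or still open, it means among the compounds named here.

Among the measured compounds shown here, in a functional assay on HCT-116 cells (Homo sapiens) for antiproliferative activity, read by MTT assay, with a stated time of 48 h (a higher number here means a weaker inhibitor, a lower number a stronger inhibitor), compound 2 `COc1ccc(-c2cc3c(cn2)[nH]c(=O)n3-c2cc(OC)c(OC)c(OC)c2)cc1` gives 840 nM, the only true number so far. Compound 1 `COc1ccc(-c2nc3cnccc3n2-c2cc(OC)c(OC)c(OC)c2)cc1O` gives > 20000 nM, which is a limit of the assay and not a number. Compound 1 carries a 3-hydroxy-4-methoxyphenyl group on a different core, so it cannot show what this group does on the core of compound 2. Compound 3 `COc1ccc(-c2cc3c(cn2)[nH]c(=O)n3-c2cc(OC)c(OC)c(OC)c2)cc1O` brings that group onto this core. Its change from compound 2 is hydroxy in place of hydrogen on an aromatic carbon, ortho to a methoxy group, turning 4-methoxyphenyl into 3-hydroxy-4-methoxyphenyl. With compound 2 at 840 nM as the sole anchor, a moderate gain in this assay is expected, though with wide uncertainty. The expected step is a 2.8-fold lower number from compound 2 to compound 3 (0.45 log units; beyond the scatter). For compound 3 the estimated value is 300 nM, with an expected range from 50 nM to 2000 nM.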

Compound 3, half-maximal inhibitory concentration: 340 nM
For compound 3 the middle estimate is 1.1-fold (0.05 log units) below the measured one; low and high end bracket the measured number.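

On the shared core, hydroxy in place of hydrogen on an aromatic carbon, ortho to a methoxy group, brings a 2.5-fold lower number from compound 2 to compound 3 (0.39 log units; beyond the scatter) in this assay, so this position accepts the change and turning 4-methoxyphenyl into 3-hydroxy-4-methoxyphenyl gives a modest gain. Among the compounds shown here, compound 1, which carries that same group on its own core, gives > 20000 nM, a limit of the assay and not a number, and no step to it can be read. Nothing given here accounts for the gain.

On these data alone, whether the gain is particular to hydroxy stays open, since an amine, a fluorine atom or an ethoxy group in the same place could give a different number. As far as these compounds go, it is also open whether the same change would give a similar step on the core of compound 1.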